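A few compounds are considered here, and "the series" means these few. Any claim that something is new, unique, unknown or untested is made for them only; others in the source may bear on it.

The two measured compounds in an ADME assay on MT4 cells (Homo sapiens) for cytotoxicity; on this read-out lower numbers stand for higher toxicity in this test and higher numbers for lower toxicity in this test:

Compound 1 `CCc1c(Cc2cccc(Br)c2)nc(SCC(=O)c2ccc(OC)cc2)[nH]c1=O` gives 142000 nM.
Compound 2 `CCc1c(Cc2ccc(Br)cc2)nc(SCC(=O)c2ccc(OC)cc2)[nH]c1=O` gives > 264000 nM, which is a limit of the assay and not a number.

Compound 2 therefore stands at the limit of > 264000 nM in this assay, at which 1 of the 2 values shown sits. Where exactly compound 2 lies beyond that limit is not known. Within the data shown here, the one measured step, an at least 1.8-fold higher number from compound 1 to compound 2 (0.26 log units; that floor lies within the scatter), comes from moving the bromo group, and its floor does not reach beyond the usual scatter, so it gives no clear direction.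

Compound 3 `CCc1c(Cc2ccc(-c3ccccc3)cc2)nc(SCC(=O)c2ccc(OC)cc2)[nH]c1=O` is the next compound, and it differs from compound 2 in one place: phenyl in place of bromo on an aromatic carbon. Among the measured compounds shown here, no measured step exchanges a bromo for a phenyl, so the only guidance is the step from compound 1 to compound 2, which was within scatter, and the fact that compound 2 is known only as a limit. On that basis no step beyond the scatter is expected in this assay, but the number for compound 3 may fall on either side of the limit. The estimate for compound 3 is 200000 nM, with a range from 60000 nM to 300000 nM. The expected step is an at least 1.3-fold lower number from compound 2 to compound 3 (0.12 log units; that floor lies within the scatter).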

Compound 3, half-maximal cytotoxic concentration: > 266000 nM
Compound 3: no number, only a limit; the forecaster's own chance of this, stated with the estimate: 40%; at least 1.3-fold (0.12 log units) between middle value and limit.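

In this assay, compound 2 and compound 3 are each known only as a limit of the assay and not as a number, so the step between them, phenyl in place of bromo, cannot be read. The compounds shown leave open where each compound lies beyond its limit, and whether this exchange changes the read-out at all.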